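The compounds below may be only part of what the source reports. "The series", "measured", "known", "first", "only" and "open" are said of these compounds alone.

Working notes on the series. Going by the values given here, in a functional assay on HeLa cells (Homo sapiens) for cytotoxicity, read by XTT assay, with a stated time of 72 h (a lower number here means a stronger inhibitor, a higher number a weaker inhibitor), compound 1 (`CCn1ccc2cc(Cc3cc(OC)c(OC)c(OC)c3)ccc21`) gives 17 nM and compound 2 (`COc1cc(Cc2ccc3c(ccn3C)c2)cc(OC)c1OC`) gives 30 nM, so compound 1 stands within the scatter of its only measured neighbour. Compound 3 (`CCn1ccc2cc(C(O)c3cc(OC)c(OC)c(OC)c3)ccc21`) carries the change (hydroxy in place of hydrogen on a saturated chain carbon bound to two aromatic carbons), which is hydroxy in place of hydrogen on a saturated chain carbon bound to two aromatic carbons. Among the compounds with values here, the one measured step, a 1.8-fold higher number from compound 1 to compound 2 (0.25 log units; within the scatter), concerns a different place, so no measured step bears directly on this change. A somewhat higher number is expected in this assay, with an estimated step of a 1.8-fold higher number from compound 1 to compound 3 (0.25 log units; within the scatter). The estimate for compound 3 is 30 nM, with an expected range from 9 nM to 100 nM.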

Compound 3, half-maximal inhibitory concentration: < 1000 nM
Compound 3 gave a limit, no number; the forecaster's own chance of this, stated with the estimate: 3%; the middle value lies beyond the limit too.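

Compound 3 gives < 1000 nM, which is a limit and not a number. The step from compound 1 to compound 3 therefore cannot be read. The compounds shown leave open what size of step hydroxy in place of hydrogen brings at this place.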